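Replacing the Benzylamino Group with a Piperidinyl Ring

A few compounds are considered here, and "the series" means these few. Any claim that something is new, unique, unknown or untested is made for them only; others in the source may bear on it.

Compound 1 `CC(C(=O)NCc1ccc(C(F)(F)F)nc1NCc1ccc(Cl)cc1)c1ccc(NS(C)(=O)=O)c(F)c1`: 65.7 nM
Compound 2 `C[C@H](C(=O)NCc1ccc(C(F)(F)F)nc1N1CC[C@@H](OCc2ccccc2)C1)c1ccc(NS(C)(=O)=O)c(F)c1`: 1.4 nM
Compound 3 `C[C@@H](C(=O)NCc1ccc(C(F)(F)F)nc1N1CCC(c2ccccc2)CC1)c1ccc(NS(C)(=O)=O)c(F)c1`: 7.5 nM

In a functional assay on CHO-K1 cells for antagonist activity at transient receptor potential cation channel subfamily V member 1 (Homo sapiens), read by FLIPR (a higher number here means a weaker inhibitor, a lower number a stronger inhibitor), compound 1 stands at the highest number of the three. Compound 3 lies nearest, with a lower number beyond the scatter, and compound 2 stands furthest, lower still and also beyond the scatter. Compound 4 `CC(C(=O)NCc1ccc(C(F)(F)F)nc1N1CCC(C(F)(F)F)CC1)c1ccc(NS(C)(=O)=O)c(F)c1` differs from compound 1 in one place: 4-(trifluoromethyl)piperidin-1-yl in place of (4-chlorobenzyl)amino on an aromatic carbon. Going by the values given here, no measured pair shows exactly this change, so the expectation rests on the other two compounds. A downward step beyond the scatter is expected, a 6.6-fold lower number from compound 1 to compound 4 (0.82 log units; beyond the scatter), because compound 3 gives 7.5 nM in this assay and compound 2 gives 1.4 nM. Compound 4 is therefore estimated at 10 nM, with a range from 3 nM to 40 nM.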

Compound 4, inhibition constant: 0.6 nM
Beside the measured number, compound 4's estimate is 17-fold (1.22 log units) above it, outside the stated range (below it).
By their numbers in this assay, from the lowest: compound 4; then compound 2; then compound 3; then compound 1.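

At this aromatic carbon next to the ring nitrogen, the swap of (4-chlorobenzyl)amino for 4-(trifluoromethyl)piperidin-1-yl gives a 110-fold lower number from compound 1 to compound 4 (2.04 log units; beyond the scatter) in this assay. The position therefore keeps strong inhibition without the six-membered aromatic ring of carbon only or the hydrogen-bond donor of the group that leaves. No measured property bears on this step, and the reason for its size remains unknown. From the compounds shown here alone, the change alters the ring and the trifluoromethyl group together, so their separate shares remain open. Also open, going by these compounds, is how a plain piperidin-1-yl or a morpholine would fare at this carbon.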